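The source may report more compounds than this note shows. Statements on the series, on what has been measured and on what is new or still open speak of the compounds shown alone.

Measured so far in a functional assay on HeLa cells (Homo sapiens) for inhibition, with a stated time of 72 h; on this read-out lower numbers stand for an effect already at smaller amounts and higher numbers for an effect only at larger amounts of compound:

- compound 1 `COc1cc(CNCc2ccncc2)ccc1OCc1ccc(C(F)(F)F)cc1`: 2400 nM
- compound 2 `COc1cc(CNCc2ccncc2)ccc1OCc1ccc(Cl)c(Cl)c1`: 4000 nM

Compound 2, at 4000 nM, stands within the usual scatter of compound 1, at 2400 nM, so this assay does not separate the two. Neither can be ranked above the other.

The next compound is compound 3 `COc1cc(CNCc2ccncc2)ccc1OCc1ccc(F)cc1`. It keeps the core of compound 2 and carries 4-fluorophenyl in place of 3,4-dichlorophenyl on a saturated chain carbon bound to an oxygen on an aromatic ring.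

Among the compounds with values here, no pair of measured compounds differs in one place only, so no measured step can serve as a direct guide. Within the data shown here, the only hint is that compound 1 at 2400 nM and compound 2 at 4000 nM carry different groups at this place and still fall within the scatter of each other. Two compounds are thin evidence, so the expectation stays wide. The expected change is a 1.1-fold higher number from compound 2 to compound 3 (0.05 log units; within the scatter), which is no step beyond the scatter and has no firm direction. For compound 3 the estimated value is 4500 nM, with an expected range from 1800 nM to 11000 nM.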

Compound 3, half-maximal effective concentration: 6400 nM
For compound 3 the middle estimate is 1.4-fold (0.15 log units) below the measured one, within the range that was stated.
By their numbers in this assay, from the lowest: compounds 1, 2 and 3 (each within the scatter of the next, the first and the last beyond it).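

In this assay, 4-fluorophenyl in place of 3,4-dichlorophenyl on a saturated chain carbon bound to an oxygen on an aromatic ring gives a step that the assay cannot tell from no change at all (a 1.6-fold higher number from compound 2 to compound 3 (0.20 log units; within the scatter)). Fluoro in place of trifluoromethyl on an aromatic carbon is different: it gives the first measured step at this place that clears the scatter, though only modestly (a 2.7-fold higher number from compound 1 to compound 3 (0.43 log units; beyond the scatter)), so the group on this ring can shift the read-out, with trifluoromethyl on the side of the lower number. Nothing measured here gives a reason for this step.

Going by these compounds, all three compounds carry a halogen or trifluoromethyl on this ring, so it remains open how a plain phenyl ring, or one bearing a methoxy group, a nitrile, an amine or a carboxylic acid, would read in this assay. On these data alone, the rest of the core is also the same in all three, so the effect of a change elsewhere, such as a longer chain in place of the link through oxygen, remains open too.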